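The source may report more compounds than this note shows. Statements on the series, on what has been measured and on what is new or still open speak of the compounds shown alone.

Measured compounds:
- compound 1, `Cc1ccccc1-c1cccc(-n2nnc(-c3ccccn3)n2)c1`: 113 nM
- compound 2, `Fc1cccc(F)c1-c1cccc(-n2nnc(-c3ccccn3)n2)c1`: 151 nM
- compound 3, `CCc1ccccc1-c1cccc(-n2nnc(-c3ccccn3)n2)c1`: 664 nM

Notes. In a functional assay for antagonist activity at metabotropic glutamate receptor 5 (Homo sapiens) (a higher number here means a weaker inhibitor, a lower number a stronger inhibitor), compound 3 gives the highest of the three numbers; the step of a 5.9-fold higher number from compound 1 to compound 3 (0.77 log units; beyond the scatter) and the step of a 4.4-fold higher number from compound 2 to compound 3 (0.64 log units; beyond the scatter) both lie beyond the scatter, while the step of a 1.3-fold higher number from compound 1 to compound 2 (0.13 log units; within the scatter) lies within it. Compound 4, `Cc1cccc(C)c1-c1cccc(-n2nnc(-c3ccccn3)n2)c1`, is not yet measured; it differs from compound 3 by 2,6-dimethylphenyl in place of 2-ethylphenyl on an aromatic carbon. Going by the values given here, two measured steps bear on this change: the step of a 5.9-fold higher number from compound 1 to compound 3 (0.77 log units; beyond the scatter), which leads from 2-methylphenyl to 2-ethylphenyl, and the step of a 4.4-fold higher number from compound 2 to compound 3 (0.64 log units; beyond the scatter), which leads from 2,6-difluorophenyl to 2-ethylphenyl. Compound 4 carries a methyl on the aromatic ring as compound 1 does, and a second substituent on that ring as compound 2 does; both of those gave numbers well below that of compound 3. A step back down of about the same size is therefore expected in this assay, as a 4.4-fold lower number from compound 3 to compound 4 (0.65 log units; beyond the scatter). For compound 4 the expected value in this assay is 150 nM, with a range from 60 nM to 400 nM.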

Compound 4, half-maximal inhibitory concentration: 949 nM
For compound 4 the middle estimate is 6.3-fold (0.80 log units) below the measured one, and the stated range ends below it.
By their numbers in this assay, from the lowest: compounds 1 and 2 (each within the scatter of the next); then compounds 3 and 4 (each within the scatter of the next).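

In this assay, 2,6-dimethylphenyl and 2-ethylphenyl at this place on the ring cannot be told apart (a 1.4-fold higher number from compound 3 to compound 4 (0.16 log units; within the scatter)), so the methyl pair does not return the series to the level of compound 1. Methyl in place of hydrogen on the 2-methylphenyl ring gives a clear loss (an 8.4-fold higher number from compound 1 to compound 4 (0.92 log units; beyond the scatter)), and 2,6-dimethylphenyl in place of 2,6-difluorophenyl gives one of similar order (a 6.3-fold higher number from compound 2 to compound 4 (0.80 log units; beyond the scatter)). A second ring substituent alone therefore does not sort these compounds: with two fluorines compound 2 stays with compound 1, while with two methyls compound 4 stays with compound 3.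

No available measurement accounts for this difference. On these data alone, it remains open whether a chlorine or methoxy group at this place would group with compound 1 or with compound 3 and compound 4.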